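Anilino series: second methoxy on the aniline ring

The source may hold more compounds than are shown below. What is called first, only, known or untested is meant among the compounds shown, and "the series" means these compounds.

Of the compounds shown here, three of the shared core have been tested in a functional assay on HGC-27 cells (Homo sapiens) for cytotoxicity, read by MTT assay, with a stated time of 72 h; on this read-out lower numbers stand for stronger inhibition and higher numbers for weaker inhibition. Compound 1 `CCCCCCCCNc1nc(SCc2ccc(C(F)(F)F)cc2)nc2ccccc12`, carrying an octyl group on the ring nitrogen, gives 13400 nM. Compound 2 `FC(F)(F)c1ccc(CSc2nc(Nc3ccccc3)c3ccccc3n2)cc1`, the anilino analogue, gives 26400 nM, and compound 3 `COc1ccc(Nc2nc(SCc3ccc(C(F)(F)F)cc3)nc3ccccc23)cc1`, the 4-methoxyphenyl analogue, gives 23500 nM. Compound 2 holds the highest of the three numbers, but none of the three is separated from another by more than the scatter: a 2.0-fold higher number from compound 1 to compound 2 (0.29 log units; within the scatter) and a 1.8-fold higher number from compound 1 to compound 3 (0.24 log units; within the scatter).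

Compound 4 `COc1ccc(Nc2nc(SCc3ccc(C(F)(F)F)cc3)nc3ccccc23)c(OC)c1` differs from compound 2 in one place: 2,4-dimethoxyphenyl in place of phenyl on a nitrogen on an aromatic ring. Among the compounds with values here, the one measured step that bears on this is the entry of a single methoxy, a 1.1-fold lower number from compound 2 to compound 3 (0.05 log units; within the scatter), which changed nothing beyond the scatter. Within the data shown here, no measured compound carries a second methoxy, so its effect cannot be read from the three numbers. The expectation for compound 4 in this assay is therefore a step of about a 1.2-fold lower number from compound 2 to compound 4 (0.08 log units; within the scatter) from compound 2, within the scatter, and an estimated value of 22000 nM, with a range from 8000 nM to 60000 nM.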

Compound 4, half-maximal inhibitory concentration: > 50000 nM
Compound 4: no number, only a limit; the forecaster's own chance of this, stated with the estimate: 10%; at least 2.2-fold (0.35 log units) between middle value and limit.
By their numbers in this assay, from the lowest: compounds 1, 3 and 2 (each within the scatter of the next). At a limit, above all of these: compound 4.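

Compound 4 stands at a limit of the assay and not at a number: the limit of > 50000 nM in this assay, at which 1 of the 4 values shown sits.

In this assay, within the data shown here, adding a methoxy on an aromatic carbon to the 4-methoxyphenyl group gives an at least 2.1-fold higher number from compound 3 to compound 4 (0.32 log units; beyond the scatter), and replacing octyl with 2,4-dimethoxyphenyl on the same nitrogen gives an at least 3.7-fold higher number from compound 1 to compound 4 (0.57 log units; beyond the scatter); these are the first steps in the set to pass the scatter, as the entry of the single methoxy had not. Measured against the unsubstituted phenyl, the reading is an at least 1.8-fold higher number from compound 2 to compound 4 (0.27 log units; that floor lies within the scatter), so only a floor is known for this step, and that floor does not by itself separate the two compounds.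

Going by these compounds, how far compound 4 lies past the limit stays open, and with it the true size of all three steps, and the set cannot tell whether the two methoxy groups act together or one of them carries the step alone. Also open, on these data alone, is how other groups on the aniline ring would read, such as a hydroxy group, an amine or a carboxylic acid, and how a chain longer than octyl would read on the same nitrogen.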